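The source may hold more compounds than are shown below. What is called first, only, known or untested is meant among the compounds shown, and "the series" means these compounds.

Measured so far in a functional assay on BE(2)-C cells (Homo sapiens) for inhibition, read by MTT assay, with a stated time of 72 h; a lower number here means a stronger inhibitor of growth, a higher number a weaker inhibitor of growth:
- compound 1 `CC(C)(C)c1ccc(CNCCCNS(=O)(=O)c2cc(C(F)(F)F)cc(C(F)(F)F)c2)cc1` gives 2500 nM
- compound 2 `O=S(=O)(NCCCNCc1ccc(Cl)c(Cl)c1)c1cc(C(F)(F)F)cc(C(F)(F)F)c1` gives 2900 nM
- compound 3 `O=S(=O)(NCCCNCc1ccc(Br)cc1)c1cc(C(F)(F)F)cc(C(F)(F)F)c1` gives 2700 nM

All three compounds share the same core and differ only in the benzyl ring attached to the amine nitrogen. Compound 3 sits within the scatter of both neighbours: the step of a 1.1-fold higher number from compound 1 to compound 3 (0.03 log units; within the scatter) and the step of a 1.1-fold lower number from compound 2 to compound 3 (0.03 log units; within the scatter) are each too small to read as a real change, so no ordering among the three is supported.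

Compound 4 `O=S(=O)(NCCCNCc1ccc(Cl)cc1)c1cc(C(F)(F)F)cc(C(F)(F)F)c1` follows from compound 3 by one exchange: chloro in place of bromo on an aromatic carbon. The two steps that bear on this are those already named, the exchange of tert-butyl for bromo from compound 1 to compound 3 and the exchange of 3,4-dichlorophenyl for 4-bromophenyl from compound 2 to compound 3; neither moved the number beyond the scatter. A swap of one halogen for another on the same aromatic carbon is a smaller change than either of those, so in this assay no step beyond the scatter is expected, in either direction. The expected step is a 1.0-fold higher number from compound 3 to compound 4 (0.02 log units; within the scatter). Compound 4 is therefore estimated at 2800 nM, with a range from 1400 nM to 5600 nM.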

Compound 4, concentration for 50% growth inhibition: 2900 nM
Estimate against measurement, compound 4: 1.0-fold (0.02 log units) below; the measured number falls inside the stated range.
By their numbers in this assay, from the lowest: compounds 1, 3, 2 and 4 (each within the scatter of the next).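

In this assay, chloro in place of bromo on the aromatic carbon para to a large group gives a 1.1-fold higher number from compound 3 to compound 4 (0.03 log units; within the scatter) and so leaves the 4-bromobenzyl and 4-chlorobenzyl groups indistinguishable. Hydrogen in place of the second chloro gives no change at the digits printed from compound 2 to compound 4 (within the scatter) and chloro in place of tert-butyl gives a 1.2-fold higher number from compound 1 to compound 4 (0.06 log units; within the scatter), so neither of these single exchanges at the ring separates compound 4 from its neighbours. Nothing available accounts for this flat response.

The compounds shown all keep a halogen or tert-butyl at this carbon, which leaves open whether hydrogen alone, an amine or a carboxylic acid there would move the number. Also open, going by these compounds, is whether a longer chain in the shared core would do so.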